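A few compounds are considered here, and "the series" means these few. Any claim that something is new, unique, unknown or untested is made for them only; others in the source may bear on it.

Among the compounds with values here, compound 2, `CCc1cc(S(=O)(=O)N2C[C@H](c3ccccc3)NC2=O)ccc1NC(=O)NC(C)C`, holds the lower of the two numbers so far in a functional assay on A549 cells (Homo sapiens) for cytotoxicity, read by MTT assay; on this read-out lower numbers stand for stronger inhibition and higher numbers for weaker inhibition. Within the data shown here, compound 1, `CCc1cc(S(=O)(=O)N2C[C@H](c3ccccc3)NC2=O)ccc1NC(=O)c1ccc([N+](=O)[O-])cc1`, gives 700 nM in this assay, while compound 2 gives 100 nM; the single measured step is a 7.0-fold lower number from compound 1 to compound 2 (0.85 log units; beyond the scatter). Compound 3, `CCc1cc(S(=O)(=O)N2C[C@H](c3ccccc3)NC2=O)ccc1NC(=O)c1ccc(N)cc1`, is the unmeasured member; it differs from compound 2 by 4-aminophenyl in place of isopropylamino on a carbonyl carbon, so an aromatic ring returns to the carbonyl carbon where compound 1 also carried one, though with an amino group in place of the nitro group of compound 1. Among the measured compounds shown here, the only step that bears on this is the one from compound 1 to compound 2, which went the other way, from an aryl to the isopropylamino group, and was modest. Because that step was a 7.0-fold lower number from compound 1 to compound 2 (0.85 log units; beyond the scatter), the return to an aryl is expected to move the number back up, though by less than the full distance since the ring itself has changed.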

Compound 3, half-maximal inhibitory concentration: 220 nM
For compound 3 the middle estimate is 1.4-fold (0.13 log units) above the measured one, and the stated range covers the measured number.
By their numbers in this assay, from the lowest: compound 2; then compound 3; then compound 1.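

In this assay, keeping an aromatic ring on the carbonyl carbon does not fix the number, since amino in place of nitro on an aromatic carbon gives a 3.2-fold lower number from compound 1 to compound 3 (0.50 log units; beyond the scatter) and shows that the group carried by the ring also counts at this position. The ring still does not match the isopropylamino group, as 4-aminophenyl in its place gives a 2.2-fold higher number from compound 2 to compound 3 (0.34 log units; beyond the scatter) and leaves compound 2 with the lowest of the three numbers. No measurement offered here explains either step.

On these data alone, whether a hydroxyl group, a methoxy group or a carboxylic acid on the ring would fall closer to amino or to nitro remains open. As far as these compounds go, it is also open whether a longer chain, such as n-butylamino, or a cyclohexylamino group on the carbonyl carbon would go lower than isopropylamino.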